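Aryl swap at the saturated ring carbon: compound 3

This account rests on a few compounds, and the source may have more. Where it says the series, first, only, none or still open, it means among the compounds named here.

Compound 1 `CC1=C(C(=O)Nc2ccc(F)c(Cl)c2)C(c2cccc(Oc3ccccc3)c2)NC(=O)N1` and compound 2 `CC1=C(C(=O)Nc2ccc(Cl)c(Cl)c2)C(c2cccc(Cl)c2)NC(=O)N1` share one core. In a functional assay on NCI/ADR-RES cells (Homo sapiens) for cytotoxicity, read by sulforhodamine B assay, with a stated time of 48 h (on this read-out higher numbers stand for weaker inhibition of growth and lower numbers for stronger inhibition of growth), compound 1 gives 16200 nM and compound 2 gives 16600 nM; the two numbers lie within the scatter of each other, so neither can be placed ahead of the other. Compound 3 `CC1=C(C(=O)Nc2ccc(Cl)c(Cl)c2)C(c2ccccc2O)NC(=O)N1` differs from compound 2 by 2-hydroxyphenyl in place of 3-chlorophenyl on a saturated ring carbon. For the measured compounds named here, no step between measured compounds bears on this exchange, so its size is unknown; a modest step in either direction, or none beyond the scatter, is expected. Compound 3 is expected to give 18000 nM, within a range from 7000 nM to 45000 nM. This estimate implies an expected step of a 1.1-fold higher number from compound 2 to compound 3 (0.04 log units; within the scatter).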

Compound 3, concentration for 50% growth inhibition: 17800 nM
Estimate against measurement, compound 3: 1.0-fold (0.00 log units) above, within the range that was stated.
By their numbers in this assay, from the lowest: compounds 1, 2 and 3 (each within the scatter of the next).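

In this assay the exchange of 3-chlorophenyl for 2-hydroxyphenyl gives a 1.1-fold higher number from compound 2 to compound 3 (0.03 log units; within the scatter) on this saturated ring carbon of the shared core. At this position, compound 2, with no hydrogen-bond donor or acceptor in the aryl group, and compound 3, with both in it, therefore cannot be told apart on this read-out. Open, from the compounds shown here alone, is whether an amine or a carboxylic acid on this phenyl ring, or a saturated alkyl chain in its place, would give a step beyond the scatter. Nothing at hand explains the size of this step.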